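This account rests on a few compounds, and the source may have more. Where it says the series, first, only, none or still open, it means among the compounds named here.

Measured compounds:
compound 1 `COc1cc(C)cc(-c2c(-c3ccnc(-c4ccc(C(C)=O)cc4)c3)cnn2CC#N)c1` with 19%
compound 2 `Cc1cc(O)cc(-c2nn(CC#N)cc2-c2ccnc(-c3ccc(Oc4ccccc4)cc3)c2)c1` with 63%
compound 3 `COc1cc(C)cc(-c2nn(CC#N)cc2-c2ccnc(-c3ccc(N(C)C)cc3)c2)c1` with -24%

In a functional assay on SK-OV-3 cells (Homo sapiens) for cytotoxicity, read by sulforhodamine B assay, with a stated time of 48 h, tested at 1 uM (on this read-out higher numbers stand for a weaker effect at the one concentration tested and lower numbers for a stronger effect), compound 3 gives -24%, the lowest of the three numbers and therefore the strongest effect at the single concentration tested. Its nearest neighbour on this read-out is compound 1, whose number is higher by a gap beyond the scatter; compound 2 sits furthest away, also beyond the scatter. Among the measured compounds shown here, no pair of the measured compounds differs in only one place, so none of these gaps can be tied to a single change.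

Compound 4 `Cc1cc(O)cc(-c2nn(CC#N)cc2-c2ccnc(-c3ccc(N(C)C)cc3)c2)c1` is the compound that has not yet been measured in this assay. It differs from compound 3 in one place: hydrogen in place of methyl on an oxygen on an aromatic ring. The set gives no direct reading of this change alone; compound 2, which carries the hydroxy, also differs elsewhere from compound 3. Compound 4 is therefore expected to move a number 34 percentage points higher from compound 3 to compound 4 (beyond the scatter), towards a weaker effect, with wide uncertainty. The estimate for compound 4 in this assay is 10%, in a range from -30% to 55%.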

Compound 4, a percentage reported as activity, at one concentration (the size of the read-out at that concentration, not a potency): -11%
Estimate against measurement, compound 4: 21 percentage points above, within the range that was stated.
By their numbers in this assay, from the lowest: compound 3; then compound 4; then compound 1; then compound 2.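

In this assay, the change from methoxy to hydroxy can now be read on its own, as a number 13 percentage points higher from compound 3 to compound 4 (beyond the scatter), and compound 4 still gives a negative number at -11%. With the hydroxy held in place, dimethylamino instead of phenoxy gives a number 74 percentage points lower from compound 2 to compound 4 (beyond the scatter), so the step at this oxygen is modest, while the exchange of those two groups is large. Nothing among the available data explains either step.

Among the compounds shown here, only one pair shows the methoxy to hydroxy change, so it remains open whether the step would keep its size with phenoxy or another group in place of dimethylamino. Going by these compounds, how an ethoxy group or a carboxylic acid at this position would read also remains open.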